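This account rests on a few compounds, and the source may have more. Where it says the series, first, only, none or still open, it means among the compounds named here.

Compound 1 `CCn1c(/C=C2/C(=O)Nc3ccccc32)nc2ccccc21` carries an ethyl group on the ring nitrogen of the shared core. In a functional assay on MDA-MB-231 cells (Homo sapiens) for cytotoxicity, read by MTT assay, with a stated time of 48 h (on this read-out lower numbers stand for stronger inhibition and higher numbers for weaker inhibition), compound 1 reaches only (the limit of > 50000 nM in this assay, at which 1 of the 3 values shown sits), so its value of > 50000 nM is a limit and not a number. Compound 2 `CC(C)n1c(/C=C2/C(=O)Nc3ccccc32)nc2ccccc21` differs by methyl in place of hydrogen on a saturated chain carbon bound to an aromatic nitrogen and a saturated chain carbon and gives 30400 nM in this assay, a change of an at least 1.6-fold lower number from compound 1 to compound 2 (0.21 log units; that floor lies within the scatter). Compound 3 `Cn1c(/C=C2/C(=O)Nc3ccc(Cl)cc32)nc2ccccc21` gives 37600 nM in this assay; the difference between its core and that of compound 1 is not broken down here. Compound 4 `CCn1c(/C=C2/C(=O)Nc3ccc(Cl)cc32)nc2ccccc21` is the still unmeasured partner of compound 3, differing by methyl in place of hydrogen on a saturated chain carbon bound to an aromatic nitrogen, the same kind of change, though here the place is on a saturated chain carbon bound to an aromatic nitrogen alone. Resting on compound 2 and its 30400 nM, a step of a 1.5-fold lower number from compound 3 to compound 4 (0.18 log units; within the scatter) is expected in this assay. Compound 4 is therefore estimated at 25000 nM, between 10000 nM and 60000 nM.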

Compound 4, half-maximal inhibitory concentration: 37500 nM
Compound 4: the middle estimate sits 1.5-fold (0.18 log units) below what was measured, and the stated range covers the measured number.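

In this assay, methyl in place of hydrogen on the core of compound 3 gives a 1.0-fold lower number from compound 3 to compound 4 (0.00 log units; within the scatter), and chloro in place of hydrogen on an aromatic carbon gives an at least 1.3-fold lower number from compound 1 to compound 4 (0.12 log units; that floor lies within the scatter). Set side by side, the methyl change on the two cores reads: the same change on two cores in this assay, an at least 1.6-fold lower number (0.21 log units; that floor lies within the scatter) from compound 1 to compound 2 and a 1.0-fold lower number (0.00 log units; within the scatter) from compound 3 to compound 4; the limit leaves it open whether they differ. So the change shows no step beyond the scatter on the core of compound 3, but this does not establish that it acts alike on the core of compound 1, whose value is a limit and not a number: the limit of > 50000 nM in this assay, at which 1 of the 4 values shown sits.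

The compounds shown leave open whether a longer chain or an amine on the aromatic nitrogen would give a clearer step. They also leave open whether a nitrile in place of chloro would do so.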